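Nitrooxyacetyl on the ring nitrogen of the furyl pyrazoline

The source may report more compounds than this note shows. Statements on the series, on what has been measured and on what is new or still open speak of the compounds shown alone.

Measured so far:
- compound 1 `COc1ccc(C2=NNC(c3ccco3)C2)cc1OC`: 60%
- compound 2 `COc1ccc(C2CC(c3ccc(OC)c(OC)c3)=NN2C(=O)CBr)c(OC)c1`: 71%

In a functional assay on the whole organism (strain albino) for inhibition, with Rattus norvegicus as the target, read by paw edema, with stated times of 30 min and 3 h, at a dose of 100 mg/kg by the oral route (on this read-out higher numbers stand for more inhibition at the one dose given (going by the name of the read-out) and lower numbers for less inhibition), compound 1 gives 60%, the lower of the two numbers; compound 2 gives 71%, a number beyond the scatter above compound 1. Compound 2 differs from compound 1 in more than one place, so no single step can be read from the pair; the two values only show that a compound carrying an acyl group on the ring nitrogen of a related core reaches the higher number.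

Compound 3 `COc1ccc(C2=NN(C(=O)CO[N+](=O)[O-])C(c3ccco3)C2)cc1OC` is not yet measured. It differs from compound 1 as follows: ((nitrooxy)methyl)carbonyl in place of hydrogen on an amine nitrogen in a ring.

Going by the values given here, no one-place step is available on this read-out, so the size of the change from compound 1 to compound 3 rests on the gap between compound 1 and compound 2 alone. The expectation is that the ((nitrooxy)methyl)carbonyl on the amine nitrogen in the ring moves the number upward, by a step that is expected to stay within the scatter, a number 8 percentage points higher from compound 1 to compound 3 (within the scatter). Compound 3 is therefore estimated at 68%, with a range from 55% to 80%.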

Compound 3, a percentage reported as inhibition, in the whole organism at one dose (the size of the read-out at that dose, not a potency): 43%
Estimate against measurement, compound 3: 25 percentage points above, outside the stated range (below it).
By their numbers in this assay, from the lowest: compound 3; then compound 1; then compound 2.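

In this assay, going by these compounds alone, ((nitrooxy)methyl)carbonyl in place of hydrogen on the amine nitrogen in the ring gives a number 17 percentage points lower from compound 1 to compound 3 (beyond the scatter), the first one-place reading. It shows that this nitrogen is not a silent position on the core of compound 1 and that this particular substituent lowers inhibition at the one dose given, so the higher number of compound 2, which differs from compound 1 in more than one place, cannot be carried over to this change. Nothing at hand bears on the reason for the drop, and the step stands as an observation only.

Within the data shown here, the single step leaves open whether the loss follows the carbonyl on the ring nitrogen or the nitrooxy end of the chain, a question that a plain acetyl or a hydroxyacetyl at the same nitrogen of the core of compound 1 would help to separate. Going by these compounds, a longer chain between the carbonyl and the nitrooxy group also remains open, as does whether the step would hold at other doses, since each number here is a read-out at one dose and not a potency.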